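Methyl to Methoxy Across Two Related Cores

The source may report more compounds than this note shows. Statements on the series, on what has been measured and on what is new or still open speak of the compounds shown alone.

Of the compounds shown here, three from one study have been tested in a functional assay on HepG2 cells (Homo sapiens) for inhibition, read by MTT assay, with a stated time of 48 h (on this read-out higher numbers stand for weaker inhibition and lower numbers for stronger inhibition), and a fourth awaits its number. Compound 1 `Cc1ccc(-n2cc(NC(=O)c3cccc(NS(=O)(=O)c4ccccc4)c3)cn2)cc1` carries a methyl group on its outer ring and gives 6050 nM in this assay. Compound 2 `COc1ccc(-n2cc(NC(=O)c3cccc(NS(=O)(=O)c4ccccc4)c3)cn2)cc1` differs from compound 1 in one place, (methoxy in place of methyl on an aromatic carbon), and in this assay compound 2 gives 35700 nM. That single change made a 5.9-fold higher number from compound 1 to compound 2 (0.77 log units; beyond the scatter), a step beyond the scatter of repeated measurements.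

Compound 3 `Cc1ccc(-n2cc(NC(=O)c3ccc(NS(=O)(=O)c4ccccc4)cc3)cn2)cc1` has the same atoms as compound 1 joined differently; the difference between the two cores is not broken down here. In this assay compound 3 gives 18100 nM, a higher number than compound 1, while its number and that of compound 2 lie within the usual scatter of each other.

For the measured compounds named here, compound 4 `COc1ccc(-n2cc(NC(=O)c3ccc(NS(=O)(=O)c4ccccc4)cc3)cn2)cc1` is to compound 3 what compound 2 is to compound 1: the change is methoxy in place of methyl on an aromatic carbon, the same change, at the same kind of place, as the one from compound 1 to compound 2. Going by the values given here, for compound 4 the step of a 4.4-fold higher number from compound 3 to compound 4 (0.65 log units; beyond the scatter) is expected, resting on the one earlier example of this change, a 5.9-fold higher number from compound 1 to compound 2 (0.77 log units; beyond the scatter), applied to the starting number of compound 3, 18100 nM, with some allowance that a single precedent on a different core may not carry over in full. Compound 4 is thus estimated at 80000 nM in this assay, most likely between 25000 nM and 250000 nM.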

Compound 4, half-maximal inhibitory concentration: 57300 nM
Compound 4: the middle estimate sits 1.4-fold (0.14 log units) above what was measured, and the stated range covers the measured number.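

In this assay, methoxy in place of methyl again gave a higher number, and so weaker inhibition, on the second core: a 3.2-fold higher number from compound 3 to compound 4 (0.50 log units; beyond the scatter). Set beside the earlier example, the two steps cannot be told apart: the same change on two cores in this assay, a 5.9-fold higher number (0.77 log units; beyond the scatter) from compound 1 to compound 2 and a 3.2-fold higher number (0.50 log units; beyond the scatter) from compound 3 to compound 4, 1.9-fold (0.27 log units) apart, within the scatter of two such steps. This shows that, in these two pairs, the change carried over from the core of compound 1 to the core of compound 3 in direction and, as far as the scatter allows a judgement, in size, so the step seen on one core was a fair guide to the step on the other; it does not show why the change acts this way, and two pairs in a single assay cannot establish a rule for other cores or other groups.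

The compounds shown carry only methyl or methoxy at this place on the outer ring, so it remains open what a chlorine atom, a hydroxyl group, an amine, a carboxylic acid or a longer chain such as ethyl would do there. On these data alone, it also remains open whether any of these groups would follow the same trend on both cores, or whether the two cores would begin to part ways.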